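Swapping One Ring on a Lipophilicity Series

The source may report more compounds than this note shows. Statements on the series, on what has been measured and on what is new or still open speak of the compounds shown alone.

Compound 1 `O=S(=O)(Nc1nccs1)c1ccc2c(c1)OCC[C@@H]2c1ccc(C(F)(F)F)cc1-c1nccs1`: 3.3
Compound 2 `O=C1COCCN1c1cc(C(F)(F)F)ccc1[C@H]1CCOc2cc(S(=O)(=O)Nc3nccs3)ccc21`: 1.8
Compound 3 `O=S(=O)(Nc1nccs1)c1ccc2c(c1)OCC[C@@H]2c1ccc(C(F)(F)F)cc1-n1ccnn1`: 2.3

In a physicochemical assay for lipophilicity (a higher number here means a more lipophilic compound, a lower number a more polar compound), compound 3, at 2.3, stands second highest of the three, below compound 1 and above compound 2. Compound 4 `O=S(=O)(Nc1nccs1)c1ccc2c(c1)OCC[C@@H]2c1ccc(C(F)(F)F)cc1-c1ccc(F)nc1` keeps the shared core and changes one group: 6-fluoropyridin-3-yl in place of 1H-1,2,3-triazol-1-yl on an aromatic carbon. For the measured compounds named here, no measured step makes this exact swap. All three measured steps do change a group at this same place, and all lie beyond the scatter: a number 1.50 log units lower from compound 1 to compound 2 (beyond the scatter), a number 1.00 log units lower from compound 1 to compound 3 (beyond the scatter) and a number 0.50 log units higher from compound 2 to compound 3 (beyond the scatter). Of the groups measured here, the 1,3-thiazol-2-yl of compound 1 looks the closest match to the entering ring, and compound 1 gives 3.3. This comparison is a judgement, not a measurement. A modest rise is therefore expected, estimated as a number 1.00 log units higher from compound 3 to compound 4 (beyond the scatter). For compound 4 the estimated value is 3.3, with an expected range from 2.8 to 3.8.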

Compound 4, distribution coefficient: 3.2
The estimate for compound 4 lay 0.10 log units above the measured number; the measured number falls inside the stated range.
By their numbers in this assay, from the lowest: compound 2; then compound 3; then compounds 4 and 1 (each within the scatter of the next).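

In this assay, 6-fluoropyridin-3-yl sits well clear of two groups at this place on the shared core, giving a number 0.90 log units higher from compound 3 to compound 4 (beyond the scatter) and a number 1.40 log units higher from compound 2 to compound 4 (beyond the scatter) as steps. The third step, a number 0.10 log units lower from compound 1 to compound 4 (within the scatter), shows that a six-membered aromatic ring and the five-membered 1,3-thiazol-2-yl can read alike here, while the equally five-membered 1H-1,2,3-triazol-1-yl does not, so ring size alone does not sort these groups. Nothing shown here gives a measured reason for these differences.

As far as these compounds go, the role of the fluorine stays open, and a plain pyridin-3-yl or phenyl ring at this place would separate it from that of the ring. Equally open, from the compounds shown here alone, is how a non-aromatic amine such as piperidine would compare with the 3-oxomorpholin-4-yl of compound 2.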